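A Bromo-for-Methyl Swap on an Arylamino Substituent

A few compounds are considered here, and "the series" means these few. Any claim that something is new, unique, unknown or untested is made for them only; others in the source may bear on it.

Of the compounds shown here, three sharing one core have been tested in a functional assay on SAOS-2 cells (Homo sapiens) for antiproliferative activity, read by MTT assay, with a stated time of 72 h; on this read-out higher numbers stand for weaker inhibition and lower numbers for stronger inhibition. Compound 1 `CC(C)OC1=C(C(=O)c2ccccc2)C(c2ccc(Br)cc2)N(CCCn2ccnc2)C1=O` gives 23000 nM. Compound 2 `NC1=C(C(=O)c2ccccc2)C(c2ccc(Br)cc2)N(CCCn2ccnc2)C1=O` gives 107000 nM, a change of a 4.7-fold higher number from compound 1 to compound 2 (0.67 log units; beyond the scatter). Compound 3 `Cc1ccc(NC2=C(C(=O)c3ccccc3)C(c3ccc(Br)cc3)N(CCCn3ccnc3)C2=O)cc1` gives 31900 nM; its number is the second highest of the three, separated from compound 1 by a 1.4-fold higher number from compound 1 to compound 3 (0.14 log units; within the scatter) and from compound 2 by a 3.4-fold lower number from compound 2 to compound 3 (0.53 log units; beyond the scatter).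

Compound 4 `O=C(C1=C(Nc2ccc(Br)cc2)C(=O)N(CCCn2ccnc2)C1c1ccc(Br)cc1)c1ccccc1` differs from compound 3 in one place: bromo in place of methyl on an aromatic carbon. Within the data shown here, none of the measured steps touches that ring; the steps that exist all change the group on the double-bonded ring carbon of the core, and the one step that most resembles a change of substituent size, a 1.4-fold higher number from compound 1 to compound 3 (0.14 log units; within the scatter), stayed within the scatter. Among the measured compounds shown here, with no direct precedent, the expectation for this assay is no step beyond the scatter in either direction.

Compound 4 is therefore estimated at 30000 nM, with a range from 10000 nM to 90000 nM. This estimate corresponds to an expected step of a 1.1-fold lower number from compound 3 to compound 4 (0.03 log units; within the scatter).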

Compound 4, half-maximal inhibitory concentration: 23800 nM
Compound 4: middle estimate off by 1.3-fold (0.10 log units), on the high side; low and high end bracket the measured number.
By their numbers in this assay, from the lowest: compounds 1, 4 and 3 (each within the scatter of the next); then compound 2.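

Among these compounds, the aromatic ring on the amine nitrogen changes here for the first time, and in this assay bromo in place of methyl on it gives a 1.3-fold lower number from compound 3 to compound 4 (0.13 log units; within the scatter), so this swap leaves the number within the scatter. The two aryl groups also compare alike with the other groups on the core: 4-bromophenyl on the amine nitrogen gives a 4.5-fold lower number from compound 2 to compound 4 (0.65 log units; beyond the scatter), much like the 4-methylphenyl step of a 3.4-fold lower number from compound 2 to compound 3 (0.53 log units; beyond the scatter), and (4-bromophenyl)amino in place of isopropoxy gives a 1.0-fold higher number from compound 1 to compound 4 (0.01 log units; within the scatter). No measurement at hand explains why this swap changes so little.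

The compounds shown leave open whether a methoxy group, a nitrile or a carboxylic acid in place of the bromo would move the number beyond the scatter. They also leave open whether a simple ethyl group on the amine nitrogen would match the aryl groups.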